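Propyl for 4-methylphenyl on the benzimidazole-bearing chain carbon

This account rests on a few compounds, and the source may have more. Where it says the series, first, only, none or still open, it means among the compounds named here.

Within the data shown here, compound 3 `Cc1ccc(Cn2c(CN3CCN(C(=O)C4CC4)CC3)nc3ccccc32)cc1` gives 51.5% in an assay on isolated protein for inhibition of aldehyde dehydrogenase 1A1 (Homo sapiens), read by spectrophotometry, tested at 10 uM (a higher number here means more inhibition at the concentration tested (going by the name of the read-out), a lower number less inhibition), the lowest of the three numbers so far. Its nearest neighbour is compound 1 `O=C(C1CC1)N1CCN(Cc2nc3ccccc3n2Cc2ccccc2C(F)(F)F)CC1`, which gives 56.3% in this assay; the gap a number 4.8 percentage points lower from compound 1 to compound 3 (within the scatter) is within the scatter. Furthest off is compound 2 `CC(C)=CCn1c(CN2CCN(C(=O)C3CC3)CC2)nc2ccccc21`, which gives 74.3%; the step of a number 22.8 percentage points lower from compound 2 to compound 3 (beyond the scatter) is beyond the scatter.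

Compound 4 `CCCCn1c(CN2CCN(C(=O)C3CC3)CC2)nc2ccccc21` is to be measured. It differs from compound 3 as follows: propyl in place of 4-methylphenyl on a saturated chain carbon bound to an aromatic nitrogen. The change that enters has no ring, whereas the change that leaves is one six-membered aromatic ring of carbon only.

Among the measured compounds shown here, two measured steps bear on this. The step of a number 18 percentage points higher from compound 1 to compound 2 (beyond the scatter) and the step of a number 22.8 percentage points lower from compound 2 to compound 3 (beyond the scatter) both exchange a ring-bearing group for a group with no ring on this carbon, or back, and in both the group with no ring gives the higher number by a modest margin beyond the scatter. The step of a number 4.8 percentage points lower from compound 1 to compound 3 (within the scatter) shows that the two ring-bearing groups read alike. A modest rise is therefore expected for compound 4. Compound 4 is estimated at 66%, within 50% to 82%, an expected step of a number 14.5 percentage points higher from compound 3 to compound 4 (beyond the scatter).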

Compound 4, a percentage reported as inhibition, at one concentration (the size of the read-out at that concentration, not a potency): 18.2%
Compound 4: the middle estimate sits 47.8 percentage points above what was measured; measured number outside the range, below it.
By their numbers in this assay, from the lowest: compound 4; then compounds 3 and 1 (each within the scatter of the next); then compound 2.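

On the saturated chain carbon bound to an aromatic nitrogen, the lack of a ring does not by itself give a higher number in this assay: propyl reads lower than both ring-bearing groups, with a number 33.3 percentage points lower from compound 3 to compound 4 (beyond the scatter) and a number 38.1 percentage points lower from compound 1 to compound 4 (beyond the scatter). The largest step, a number 56.1 percentage points lower from compound 2 to compound 4 (beyond the scatter), lies between two groups with no ring, propyl and 2-methylprop-1-en-1-yl, so ring against no ring does not sort these four compounds, and compound 2 goes against any such pattern. No measured evidence available here accounts for this difference.

The compounds shown leave open whether the low number is particular to propyl or extends to other saturated groups on this carbon. A longer chain such as pentyl, a branched 2-methylpropyl group or a saturated cyclohexyl ring would each test this.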